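This account rests on a few compounds, and the source may have more. Where it says the series, first, only, none or still open, it means among the compounds named here.

Of the compounds shown here, three built on the shared core have been measured in an assay on isolated protein (spleen, strain Sprague-Dawley) for antagonist activity at Alpha-1B adrenergic receptor (Rattus norvegicus), with a stated time of 20 min; a lower number here means tighter binding, a higher number weaker binding. Compound 1 `COc1ccccc1N1CCN(CCCNC(=O)Cc2c[nH]c3ccccc23)CC1` gives 513 nM. Compound 2 `COc1ccccc1N1CCN(CCCNC(=O)CCCc2c[nH]c3ccccc23)CC1`, which carries a longer chain on the amide side, gives 95.5 nM, a lower number than compound 1 and beyond the scatter. Compound 3 `COc1ccc2[nH]c(C(=O)NCCCN3CCN(c4ccccc4OC)CC3)cc2c1`, in which the bicyclic ring is joined directly to the carbonyl, gives 1450 nM, a higher number than compound 1 and again beyond the scatter. Compound 1 therefore stands second highest of the three, with compound 3 the nearer neighbour and compound 2 the more distant one.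

Compound 4 `COc1ccccc1N1CCN(CCCNC(=O)c2cc3cc(Cl)ccc3[nH]2)CC1` has not yet been measured. It differs from compound 1 in one place: 5-chloro-1H-indol-2-yl in place of (1H-indol-3-yl)methyl on a carbonyl carbon. Within the data shown here, no measured pair shows this exact change, so the size of the step can only be judged from compound 3, whose value 1450 nM lies above that of compound 1 and shares with compound 4 the direct attachment to the carbonyl. The step of a 1.6-fold higher number from compound 1 to compound 4 (0.19 log units; within the scatter) is expected to run toward a higher number, of modest size and possibly within the scatter. Compound 4 is estimated at 800 nM, with a range from 250 nM to 2500 nM.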

Compound 4, dissociation constant: 257 nM
Compound 4: the middle estimate sits 3.1-fold (0.49 log units) above what was measured, and the stated range covers the measured number.
By their numbers in this assay, from the lowest: compound 2; then compounds 4 and 1 (each within the scatter of the next); then compound 3.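

In this assay, 5-chloro-1H-indol-2-yl in place of (1H-indol-3-yl)methyl on a carbonyl carbon gives a 2.0-fold lower number from compound 1 to compound 4 (0.30 log units; within the scatter) and so stays level with compound 1, which shows that this position tolerates the exchange of one group of this size for the other. Among these compounds, until now the only compound with its ring joined directly to the carbonyl was compound 3, which stood highest, but chloro in place of methoxy on an aromatic carbon gives a 5.6-fold lower number from compound 3 to compound 4 (0.75 log units; beyond the scatter) and thus shows that direct attachment does not by itself set the number, since the group on the aromatic carbon counts for a step beyond the scatter. Nothing given here offers a reason for either step.

Going by these compounds, the step from compound 1 changes the attachment and adds chloro at once, so the share of each stays open, and the same ring carrying hydrogen in place of chloro would be needed to separate them. Also open, on these data alone, is whether fluoro or methyl on that aromatic carbon would match chloro, and whether chloro would hold on the longer chain of compound 2.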